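Cytotoxicity notes on a quinoxaline-type diamine series

A few compounds are considered here, and "the series" means these few. Any claim that something is new, unique, unknown or untested is made for them only; others in the source may bear on it.

The shared core is carried by compound 1 `Nc1cc(N)c2nc(-c3ccccc3)c(Sc3ccc(F)cc3)nc2c1`, compound 2 `CCOC(=O)[C@H](CCC(=O)O)NC(=O)c1ccc(Oc2nc3cc(N)cc(N)c3nc2-c2ccccc2)cc1` and the unmeasured compound 3 `COc1ccc(Sc2nc3cc(N)cc(N)c3nc2-c2ccccc2)cc1`. In a functional assay on OVCAR-5 cells (Homo sapiens) for inhibition, read by sulforhodamine B assay, with a stated time of 48 h (on this read-out higher numbers stand for lower toxicity in this test and lower numbers for higher toxicity in this test), compound 1 gives < 100000 nM, which is a limit of the assay rather than a number. In this assay compound 2 likewise gives < 100000 nM, again a limit. Within the data shown here, compound 1 therefore stands only at a limit, and the one further value shown is also a limit (the limit of < 100000 nM in this assay, at which 2 of the 2 values shown sit). Compound 3 differs from compound 1 by methoxy in place of fluoro on an aromatic carbon, on the aromatic carbon para to a large group. Among the measured compounds shown here, no step between measured compounds is available, so the step from compound 1 to compound 3 is expected to be no larger than the scatter, estimated as a step that the limit leaves unreadable from compound 1 to compound 3. Compound 3 is accordingly expected to give 30000 nM, within an estimated range of 5000 nM to 100000 nM, with a fair chance that only a limit is again reported.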

Compound 3, concentration lethal to 50% of the cells: < 100000 nM
Compound 3: a limit, no number; the forecaster's own chance of this, stated with the estimate: 55%; the middle value is on the limit's open side.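

Compound 1 and compound 3 both stop at a limit and not at a number, so no step between them can be read: the limit of < 100000 nM in this assay, at which 3 of the 3 values shown sit.

The compounds shown leave open whether methoxy in place of fluoro changes the read-out at all.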